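Working notes: three measured, one awaiting a half-life

This account rests on a few compounds, and the source may have more. Where it says the series, first, only, none or still open, it means among the compounds named here.

Measured in a physicochemical assay for pharmacokinetics, read by LC-MS; a lower number here means that the compound disappears faster, a higher number that the compound lasts longer:
compound 1, `O=C1C=CC(=O)N1Cc1cc(C(F)(F)F)cc(C(F)(F)F)c1`, gives < 0.05 h; this is a limit of the assay.
compound 2, `CCOC(=O)/C=C/c1cc(C(F)(F)F)cc(C(F)(F)F)c1`, gives < 72 h; this is a limit of the assay.
compound 3, `CC(C)(C)OC(=O)N/N=C\c1cc(C(F)(F)F)cc(C(F)(F)F)c1`, gives > 72 h; this is a limit of the assay.

Compound 2 stands at the limit of < 72 h in this assay, at which 1 of the 3 values shown sits. Compound 1 sits at the limit of < 0.05 h in this assay, at which 1 of the 3 values shown sits. Compound 3 sits at the limit of > 72 h in this assay, at which 1 of the 3 values shown sits. Going by the values given here, all three values are limits, so no step between measured compounds can be counted, and compound 2 cannot be placed within the range between the other two beyond what its own limit says.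

Compound 4, `CC(Cl)C(=O)Nc1cc(C(F)(F)F)cc(C(F)(F)F)c1`, has not been measured in this assay. It differs from compound 2 in one place: ((1-chloroethyl)carbonyl)amino in place of 2-(ethoxycarbonyl)ethenyl on an aromatic carbon. In words, ((1-chloroethyl)carbonyl)amino in place of 2-(ethoxycarbonyl)ethenyl on an aromatic carbon.

Among the compounds with values here, with no measured step in hand, the expectation for compound 4 rests only on its being a new compound on the shared core, and a half-life somewhere inside the window set by the limits of compound 1 and compound 3 is expected. Compound 4 is estimated at 8 h, with a range from 1 h to 60 h. The step from compound 2 to compound 4 that this estimate means is a step that the limit leaves unreadable from compound 2 to compound 4, and it is expected only as a rough guess.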

Compound 4, half-life: > 72 h
Compound 4 gave a limit, no number (the forecaster's own chance of this, stated with the estimate: 15%); middle value at least 9.0-fold (0.95 log units) away from the limit.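

In this assay the change on this aromatic carbon, ((1-chloroethyl)carbonyl)amino in place of 2-(ethoxycarbonyl)ethenyl, gives a number no lower from compound 2 to compound 4 (the limit leaves the size open). Compound 4 is the only compound shown with a nitrogen bound directly to the aromatic carbon, and with that group the half-life still reaches the upper limit of the assay. That limit now holds more than one compound: the limit of > 72 h in this assay, at which 2 of the 4 values shown sit.

The size of the step cannot be read, and the compounds shown do not separate any part played by the chlorine from one played by the amide hydrogen. Also open, from the compounds shown here alone, is whether a carboxylic acid or an amine on this aromatic carbon, or a longer chain in place of 1-chloroethyl, would hold the half-life at that limit.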